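Phenyl in Place of a Substituted Aryl Ring

The compounds below may be only part of what the source reports. "The series", "measured", "known", "first", "only" and "open" are said of these compounds alone.

Of the compounds shown here, three from this study have been measured in an ADME assay on KB cells (Homo sapiens) for cytotoxicity, read by MTT assay, with a stated time of 72 h; a higher number here means a weaker inhibitor, a lower number a stronger inhibitor. Compound 1 `COC(=O)c1cc(C2=C(c3cc(OC)c(OC)c(OC)c3)C(=O)CC2O[SiH2]C(C)(C)C)ccc1OC` reaches only the limit of the assay, giving > 100 ug/mL. Compound 2 `COCOc1cc(C2=C(c3cc(OC)c(OC)c(OC)c3)C(=O)CC2O[SiH2]C(C)(C)C)ccc1OC` gives 33 ug/mL. Compound 3 `COc1cc(C2=C(c3ccc(OCC(=O)O)cc3)C(O)CC2=O)cc(OC)c1OC` likewise sits at the limit, giving > 100 ug/mL. Going by the values given here, the one step measured between neighbours, an at least 3.0-fold lower number from compound 1 to compound 2 (0.48 log units; beyond the scatter), is the only guide to how the aryl ring carrying these groups behaves; the limit of > 100 ug/mL in this assay, at which 2 of the 3 values shown sit, holds for two of the three, so compound 2 stands as the only compound with a number rather than a limit.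

Compound 4 `COc1cc(C2=C(c3ccccc3)C(O[SiH2]C(C)(C)C)CC2=O)cc(OC)c1OC` has not yet been measured. It differs from compound 2 by phenyl in place of 4-methoxy-3-(methoxymethoxy)phenyl on a double-bonded ring carbon. Among the compounds with values here, no measured step strips the whole set of substituents from this ring; the step from compound 1 to compound 2 only exchanged one group for another there, yet it was large enough to show that this ring matters. A modest rise in the number, in the direction of weaker inhibition, is therefore expected. Compound 4 is estimated to give 65 ug/mL (from 20 ug/mL to 150 ug/mL). The step that this estimate implies is a 2.0-fold higher number from compound 2 to compound 4 (0.29 log units; within the scatter).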

Compound 4, half-maximal inhibitory concentration: > 100 ug/mL
Compound 4: only a limit was reported; the forecaster's own chance of this, stated with the estimate: 35%; middle value at least 1.5-fold (0.18 log units) away from the limit.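

In this assay, phenyl in place of 4-methoxy-3-(methoxymethoxy)phenyl on this double-bonded ring carbon gives an at least 3.0-fold higher number from compound 2 to compound 4 (0.48 log units; beyond the scatter), so the unsubstituted phenyl does not keep the measurable value of compound 2. Compound 4 now also stands at a limit rather than at a number: the limit of > 100 ug/mL in this assay, at which 3 of the 4 values shown sit. The comparison of compound 1 with compound 4 cannot be read, so the ring carrying methoxycarbonyl and the plain phenyl cannot be placed in order.

The compounds shown leave open whether the methoxy or the methoxymethoxy group accounts for the difference, since the two leave together in this change. They also leave open whether another group on this ring, such as an amine or a fluorine, would give a number stronger than that of compound 2.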